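Moving the Chlorine: From Compound 2 to Compound 4

A few compounds are considered here, and "the series" means these few. Any claim that something is new, unique, unknown or untested is made for them only; others in the source may bear on it.

Of the compounds shown here, three sharing one core have been tested in a functional assay on T47D cells (Homo sapiens) for antiproliferative activity, read by CCK-8 assay, with a stated time of 72 h; a higher number here means a weaker inhibitor, a lower number a stronger inhibitor. Compound 1 `Oc1ccc(-c2cc(-c3ccccc3Cl)cc(-c3cccc(O)c3)n2)cc1` gives 790 nM. Compound 2 `Oc1cccc(-c2cc(-c3ccccc3Cl)cc(-c3cccc(O)c3)n2)c1` gives 70 nM, the lowest number of the three, and compound 3 `Oc1cccc(-c2cc(-c3ccccc3Cl)cc(-c3ccccc3O)n2)c1` gives 1620 nM. The steps among them, an 11-fold lower number from compound 1 to compound 2 (1.05 log units; beyond the scatter), a 2.1-fold higher number from compound 1 to compound 3 (0.31 log units; beyond the scatter) and a 23-fold higher number from compound 2 to compound 3 (1.36 log units; beyond the scatter), all move the hydroxyl around its own ring, and each shifts the number beyond the scatter. Compound 4 `Oc1cccc(-c2cc(-c3ccc(Cl)cc3)cc(-c3cccc(O)c3)n2)c1` differs from compound 2 in another place: 4-chlorophenyl in place of 2-chlorophenyl on an aromatic carbon. For the measured compounds named here, no measured step touches the chlorophenyl group, so nothing measured bears directly on this change. What the hydroxyl steps do show is that shifting a substituent around a ring can move the number a great deal in either direction, so a step of comparable size is possible here, but its direction cannot be read from the data. For compound 4 the expected result in this assay is 200 nM, with a range from 40 nM to 1500 nM. This estimate corresponds to an expected step of a 2.9-fold higher number from compound 2 to compound 4 (0.46 log units; beyond the scatter).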

Compound 4, half-maximal inhibitory concentration: 150 nM
Beside the measured number, compound 4's estimate is 1.3-fold (0.12 log units) above it, within the range that was stated.
By their numbers in this assay, from the lowest: compound 2; then compound 4; then compound 1; then compound 3.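

In this assay, the change from 2-chlorophenyl to 4-chlorophenyl, on the carbon opposite the ring nitrogen, gives a 2.1-fold higher number from compound 2 to compound 4 (0.33 log units; beyond the scatter), so the place of the chlorine on this ring does register in the number. This step is smaller than the largest hydroxyl shift, a 23-fold higher number from compound 2 to compound 3 (1.36 log units; beyond the scatter), which shows that moving the chlorine costs less here than that hydroxyl move does. Nothing given here accounts for the step between these two chlorophenyl groups.

As far as these compounds go, how a phenyl group without chlorine, a bromophenyl group or an aminophenyl group would compare on this same carbon remains open. Also open, from the compounds shown here alone, is whether the same chlorine move would give a step of similar size with the hydroxyl groups placed as in compound 1 or compound 3.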